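The source may hold more compounds than are shown below. What is called first, only, known or untested is meant among the compounds shown, and "the series" means these compounds.

Compound 1, `CCC(=O)Nc1ccc(-c2nc3cc(C(F)(F)F)ccc3[nH]2)cc1`, in an ADME assay on BHK cells (Mesocricetus auratus) for cytotoxicity, read by MTT assay, with a stated time of 96 h; on this read-out lower numbers stand for higher toxicity in this test and higher numbers for lower toxicity in this test: 100000 nM
Compound 2, `O=C(CCl)Nc1ccc(-c2nc3cc(C(F)(F)F)ccc3[nH]2)cc1`, in this assay: 22000 nM

For the measured compounds named here, compound 2 gives the lowest of the two numbers so far; its nearest neighbour is compound 1, and the step of a 4.5-fold lower number from compound 1 to compound 2 (0.66 log units; beyond the scatter) separates them. Compound 3, `O=C(CN1CCCC1)Nc1ccc(-c2nc3cc(C(F)(F)F)ccc3[nH]2)cc1`, is not yet measured. It differs from compound 2 in one place: pyrrolidin-1-yl in place of chloro on a saturated chain carbon bound to a carbonyl carbon. Going by the values given here, only one measured step touches the same saturated chain carbon bound to a carbonyl carbon, namely a 4.5-fold lower number from compound 1 to compound 2 (0.66 log units; beyond the scatter), where the chloro group entered and the number fell. Among the compounds with values here, no measured pair shows the pyrrolidin-1-yl group itself, so the direction of the new step is uncertain. The expectation here is that removing the chloro group returns compound 3 toward the number of compound 1, giving an estimated step of a 2.7-fold higher number from compound 2 to compound 3 (0.44 log units; beyond the scatter). For compound 3 the estimate in this assay is therefore 60000 nM, within a range from 20000 nM to 150000 nM.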

Compound 3, half-maximal cytotoxic concentration: 29000 nM
Compound 3: the middle estimate sits 2.1-fold (0.32 log units) above what was measured, and the stated range covers the measured number.
By their numbers in this assay, from the lowest: compounds 2 and 3 (each within the scatter of the next); then compound 1.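

In this assay, pyrrolidin-1-yl in place of chloro on this saturated chain carbon bound to a carbonyl carbon gives a 1.3-fold higher number from compound 2 to compound 3 (0.12 log units; within the scatter), so compound 2 and compound 3 cannot be told apart here. Against the methyl group, the same ring gives a 3.4-fold lower number from compound 1 to compound 3 (0.54 log units; beyond the scatter), which shows that the lower number is not unique to chloro: a single atom and a ring of five heavy atoms give matching results. Nothing measured here accounts for this match.

From the compounds shown here alone, whether other groups on this carbon would match compound 2 and compound 3 or return toward compound 1 remains open, for example an open-chain amine such as dimethylamino, a morpholine ring or a hydroxyl group. Also open, going by these compounds, is how a longer chain carrying the pyrrolidin-1-yl group would read out.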